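Oxazole ketone series: acid replaced by dimethylcarbamoyl

The source may report more compounds than this note shows. Statements on the series, on what has been measured and on what is new or still open speak of the compounds shown alone.

Measured compounds:
compound 1 `O=C(O)c1ccc(-c2cnc(C(=O)CCc3ccc(-c4ccccc4)cc3)o2)cn1` — 44 nM
compound 2 `COC(=O)c1cnc(C(=O)CCc2ccc(COc3ccccc3)cc2)o1` — 1.6 nM
compound 3 `O=C(O)c1ccc(-c2cnc(C(=O)CCc3ccc(-c4ccccc4)cc3)o2)nc1` — 14 nM

In an assay for inhibition of Fatty-acid amide hydrolase 1 (Rattus norvegicus) (on this read-out lower numbers stand for stronger inhibition and higher numbers for weaker inhibition), compound 1 gives the highest of the three numbers. Compound 3, its nearest neighbour, differs only in the carboxypyridyl group on the shared core and shows a 3.1-fold lower number from compound 1 to compound 3 (0.50 log units; beyond the scatter). Compound 2 stands furthest away, but it differs from compound 1 in two places at once, the group on the core and the tail beyond the ketone, so its value can only be noted alongside that of compound 1 and not broken down into steps.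

Compound 4 `CN(C)C(=O)c1cnc(C(=O)CCc2ccc(-c3ccccc3)cc2)o1` is not yet measured. Against compound 1 the change is dimethylcarbamoyl in place of 6-carboxypyridin-3-yl on an aromatic carbon. Among the compounds with values here, no measured step covers this kind of exchange: the step from compound 1 to compound 3 swaps one carboxypyridyl for another, and its modest size says little about removing the ring and the acid altogether. Compound 2 hints that a small carbonyl-bearing substituent on the core is compatible with a low number, without separating that from its different tail.

With that weak footing, compound 4 is expected to show a 4.4-fold lower number from compound 1 to compound 4 (0.64 log units; beyond the scatter), a move toward lower numbers that could also fall within the scatter. The estimate for compound 4 is 10 nM, in the range 2 nM to 50 nM.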

Compound 4, inhibition constant: 3 nM
Beside the measured number, compound 4's estimate is 3.3-fold (0.52 log units) above it; the range from low to high includes it.
By their numbers in this assay, from the lowest: compounds 2 and 4 (each within the scatter of the next); then compound 3; then compound 1.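

At the aromatic carbon next to the ring oxygen, the six-membered aromatic ring and the carboxylic acid of the carboxypyridyl groups prove dispensable for a low number in this assay: dimethylcarbamoyl, which has no ring and no hydrogen-bond donor, gives a large step (a 15-fold lower number from compound 1 to compound 4 (1.17 log units; beyond the scatter)) and a modest one (a 4.7-fold lower number from compound 3 to compound 4 (0.67 log units; beyond the scatter)). Compound 4 carries the tail of compound 1, so this low number belongs to the change of group on the core alone, a reading that compound 2, with its different tail, could not support. Nothing in the data gives a reason for the size of these steps.

The compounds shown do not separate the loss of the ring from the loss of the acid or from the entry of the amide, and a plain pyridyl ring without the carboxylic acid, or a primary amide or methyl ester on the same tail, would address that. From the compounds shown here alone, whether dimethylcarbamoyl and the methyl ester of compound 2 differ at all on a common tail also remains open.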